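Swapping a halogen pattern on a shared core

The source may report more compounds than this note shows. Statements on the series, on what has been measured and on what is new or still open speak of the compounds shown alone.

Compound 1, `CC1(C)C=Cc2c(ccc(C(=O)/C=C/c3ccc(F)cc3)c2O)O1`: 158000 nM
Compound 2, `CC1(C)C=Cc2c(ccc(C(=O)/C=C/c3ccc(Br)cc3)c2O)O1`: "not determined" (no result reported)

In an ADME assay on Vero cells (Chlorocebus sabaeus) for cytotoxicity, read by MTT assay, with a stated time of 72 h (on this read-out lower numbers stand for higher toxicity in this test and higher numbers for lower toxicity in this test), compound 1 gives 158000 nM. Compound 2 was included in the same test, but for compound 2 the outcome is "not determined" (no result reported), so compound 2 cannot be placed on this scale at all; the only anchor among the measured compounds is compound 1. Compound 3, `CC1(C)C=Cc2c(ccc(C(=O)/C=C/c3ccc(Cl)c(Cl)c3)c2O)O1`, differs from compound 2 in one place: 3,4-dichlorophenyl in place of 4-bromophenyl on a double-bonded chain carbon bound to a double-bonded chain carbon. No measured step exists between any two of these compounds, so the size and direction of the change from compound 2 to compound 3 in this assay cannot be read from data. Taking compound 1 as the nearest reference, the expectation is a step of no more than the usual scatter, if anything toward somewhat higher toxicity. Compound 3 is therefore estimated at 100000 nM, with a range from 30000 nM to 300000 nM.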

Compound 3, half-maximal cytotoxic concentration: 142000 nM
Compound 3: the middle estimate sits 1.4-fold (0.15 log units) below what was measured; measured number inside the range.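

Compound 3 gives this position its first readable step, and in this assay that step is a 1.1-fold lower number from compound 1 to compound 3 (0.05 log units; within the scatter). On this read-out, 3,4-dichlorophenyl and 4-fluorophenyl at this place on the shared core therefore cannot be told apart, so this swap of one halogen pattern for another leaves the two compounds no further apart than repeat measurements of a single compound might be. Nothing available here offers an explanation for this result.

Steps to or from compound 2 cannot be read, so the standing of 4-bromophenyl in this series remains unknown. Both readable compounds carry only halogens on this phenyl ring, which leaves open how the number in this assay would respond to an amine or a carboxylic acid in their place.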